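Swapping the Ester for a Thiazole on a Shared Core

This account rests on a few compounds, and the source may have more. Where it says the series, first, only, none or still open, it means among the compounds named here.

In a toxicity assay on NIH3T3 cells (Mus musculus) for cytotoxicity, read by resazurin assay (a higher number here means that more compound is needed for the effect, a lower number that less compound is needed), three compounds of this series have been measured, and none of them gave a number. Compound 1, `Cc1cccc(-c2cccc(NCc3cncn3Cc3ccccc3)c2)c1`, gives > 1000 nM, which is a limit of the assay and not a measured value; it sits at the limit of > 1000 nM in this assay, at which 1 of the 3 values shown sits. Compound 2, `COC(=O)c1ccc(NCc2cncn2Cc2cccc(Br)c2)cc1-c1ccccc1`, gives > 10000 nM, again a limit of the assay. Compound 3, `O=C(OC1CCCCC1)c1ccc(NCc2cncn2Cc2ccc(-c3ccccc3)cc2)cc1-c1ccccc1`, likewise gives > 10000 nM, a limit of the assay, so that compound 3 stands together with compound 2 at the limit of > 10000 nM in this assay, at which 2 of the 3 values shown sit. Every value is a limit. Going by the values given here, no step between measured compounds can be stated.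

Compound 4, `c1ccc(-c2ccc(Cn3cncc3CNc3ccc(-c4cncs4)c(-c4ccccc4)c3)cc2)cc1`, has not yet been measured. It differs from compound 3 in one place: 1,3-thiazol-5-yl in place of cyclohexyloxycarbonyl on an aromatic carbon. Among the compounds with values here, nothing among the measured compounds points to a change in either direction, so no step beyond the usual scatter is expected for compound 4; the expected step is a number no higher from compound 3 to compound 4 (the limit leaves the size open). Compound 4 is therefore estimated to give about 10000 nM, with a range from 3000 nM to 30000 nM, and most likely it will again be reported only as a limit.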

Compound 4, half-maximal effective concentration: > 1000 nM
Compound 4 gave a limit, no number (the forecaster's own chance of this, stated with the estimate: 80%); the middle value is on the limit's open side.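

In this assay, going by these compounds alone, compound 3 and compound 4 both gave only limits of the assay, not numbers, so no step between them can be read. The compounds shown leave open whether 1,3-thiazol-5-yl in place of cyclohexyloxycarbonyl changes the concentration needed, and at what concentration any of them would give a number.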